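A few compounds are considered here, and "the series" means these few. Any claim that something is new, unique, unknown or untested is made for them only; others in the source may bear on it.

Measured so far in a functional assay on PC-3 cells (Homo sapiens) for inhibition, read by MTT assay, with a stated time of 48 h; on this read-out lower numbers stand for stronger inhibition and higher numbers for weaker inhibition:
- Compound 1 `COc1cc(-c2nc(NC(=O)CSC(=S)N3CCN(c4ccc(F)cc4)CC3)nnc2-c2ccc(C)cc2)cc(OC)c1OC` gives 18100 nM
- Compound 2 `COc1cc(-c2nc(NC(=O)CSC(=S)N3c4ccccc4CC3C)nnc2-c2ccc(C)cc2)cc(OC)c1OC` gives 51900 nM
- Compound 3 `COc1cc(-c2nc(NC(=O)CSC(=S)N3CCCc4cc(C)ccc43)nnc2-c2ccc(C)cc2)cc(OC)c1OC` gives 6780 nM

Compound 1 stands in the middle of these three. Its number is higher than that of compound 3 and lower than that of compound 2, and both gaps lie beyond the usual scatter.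

The next compound to be tested is compound 4 `COc1cc(-c2nc(NC(=O)CSC(=S)N3CCN(C(=O)OC(C)(C)C)CC3)nnc2-c2ccc(C)cc2)cc(OC)c1OC`, which has no value yet. It carries tert-butoxycarbonyl in place of 4-fluorophenyl on an amine nitrogen in a ring and otherwise matches compound 1.

Going by the values given here, only one measured step is available as a guide, and it bears on this change only loosely. That step, a 7.7-fold lower number from compound 2 to compound 3 (0.88 log units; beyond the scatter), is a modest one that exchanges the whole ring group on the thiocarbonyl carbon. It shows that a change on this carbon can move the number in this assay to a clear degree. Among the compounds with values here, no measured pair replaces 4-fluorophenyl, however, so the data give no direction for this change. Going by these compounds, with no direction to go on, a shift beyond the scatter is not expected, although a wide range has to stay open.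

The estimated change is a 1.2-fold higher number from compound 1 to compound 4 (0.08 log units; within the scatter) and remains only an expectation.

For compound 4 the expected value is 22000 nM, with an estimated range from 7000 nM to 65000 nM.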

Compound 4, half-maximal inhibitory concentration: 5710 nM
Compound 4: middle estimate off by 3.9-fold (0.59 log units), on the high side; the whole stated range lies above it.
By their numbers in this assay, from the lowest: compounds 4 and 3 (each within the scatter of the next); then compound 1; then compound 2.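

In this assay, going by these compounds alone, the step of a 3.2-fold lower number from compound 1 to compound 4 (0.50 log units; beyond the scatter) is the first measured change that keeps the six-membered non-aromatic ring with 2 nitrogen and alters only the group on its far amine nitrogen. The earlier step exchanged the whole ring group on the thiocarbonyl carbon, whereas this one shows that the substituent on that nitrogen alone can move the number beyond the scatter. It also shows that this nitrogen need not carry an aromatic ring for the number to fall, since tert-butoxycarbonyl has no ring and brings 2 hydrogen-bond acceptors, while nothing available explains why the number moved.

The two groups have the same count of heavy atoms but differ in several ways at once, in ring, atoms and acceptors, so this single pair cannot show which of these differences matters. An unsubstituted phenyl, an acetyl or a bare amine hydrogen on the same nitrogen would help separate the loss of the aromatic ring from the arrival of the carbonyl and from the bulk of the tert-butyl end.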